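The source may report more compounds than this note shows. Statements on the series, on what has been measured and on what is new or still open speak of the compounds shown alone.

Measured so far:
compound 1 `O=C(/C=C/c1ccc([N+](=O)[O-])cc1)Nc1cc(Sc2ncn[nH]2)c(O)c2ccccc12` gives 40.6%
compound 2 `O=C(Nc1cc(Sc2ncn[nH]2)c(O)c2ccccc12)c1ccc([N+](=O)[O-])cc1` gives 37.3%

In an assay on isolated protein for inhibition of RAC-alpha serine/threonine-protein kinase (Homo sapiens), read by fluorescence, with a stated time of 30 min, tested at 10 uM (on this read-out lower numbers stand for less inhibition and higher numbers for more inhibition at the one concentration tested (going by the name of the read-out)), compound 1 gives 40.6% and compound 2 gives 37.3%. Compound 2 has the lower of the two numbers, but the gap to compound 1 lies within the scatter, so the two cannot be placed in any order on this assay. Among the measured compounds shown here, no step between compounds that differ in one place has been characterised, so there is no measured step to lean on.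

Compound 3 `O=C(Nc1cc(Sc2ncn[nH]2)c(O)c2ccccc12)c1cccc([N+](=O)[O-])c1` is not yet measured. It differs from compound 2 in one place: 3-nitrophenyl in place of 4-nitrophenyl on a carbonyl carbon. The two have the same atoms, joined differently. For the measured compounds named here, with no comparable step, the expectation is for no change beyond the scatter, in either direction. The estimated step of a number 1.3 percentage points lower from compound 2 to compound 3 (within the scatter) is therefore near zero. Compound 3 is expected to give 36% in this assay, with a range from 18% to 54%.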

Compound 3, a percentage reported as inhibition, at one concentration (the size of the read-out at that concentration, not a potency): 29.3%
The estimate for compound 3 lay 6.7 percentage points above the measured number, and the stated range covers the measured number.
By their numbers in this assay, from the lowest: compounds 3, 2 and 1 (each within the scatter of the next, the first and the last beyond it).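

In this assay, 3-nitrophenyl in place of 4-nitrophenyl on a carbonyl carbon gives a number 8 percentage points lower from compound 2 to compound 3 (within the scatter) in the first step read at a single place in this series. With the same atoms joined differently, this change does not separate compound 2 and compound 3, and the two cannot be placed in order on this read-out. No measurement at hand bears on the size of this step.

Open, on these data alone, is whether an unsubstituted phenyl, or a phenyl carrying an amine or a carboxylic acid instead of the nitro group, on the same carbonyl carbon would stand apart from compound 2 beyond the scatter. Also open, as far as these compounds go, is whether 3-nitrophenyl in place of 4-nitrophenyl would give a comparable step in the setting of compound 1.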